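Swapping the aryl on a ring nitrogen in a kinase-type scaffold

The compounds below may be only part of what the source reports. "The series", "measured", "known", "first", "only" and "open" are said of these compounds alone.

The measured set is small. Compound 1 `COc1cc2c(Oc3ccc(NC(=O)c4nn(-c5ccccc5C)c(=O)cc4C)cc3F)ccnc2cc1OCCCN1CCCCC1` is tested in a functional assay on NCI-H460 cells (Homo sapiens) for inhibition, read by MTT assay, with a stated time of 72 h (on this read-out higher numbers stand for weaker inhibition and lower numbers for stronger inhibition), and gives 3220 nM. Compound 2 `COc1cc2c(Oc3ccc(NC(=O)c4nn(-c5ccccc5C)c(=O)cc4C)cc3F)ccnc2cc1OCCCN1CCN(C)CC1` is its closest relative, and in this assay compound 2 gives 3420 nM. Compound 1 therefore stands as the lower of the two numbers, but only by a 1.1-fold higher number from compound 1 to compound 2 (0.03 log units; within the scatter), which is a change at the far end of the chain that carries the saturated amine.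

Compound 3 `COc1ccc(-n2nc(C(=O)Nc3ccc(Oc4ccnc5cc(OCCCN6CCCCC6)c(OC)cc45)c(F)c3)c(C)cc2=O)cc1` keeps the shared core of compound 1 and changes a different part of it: 4-methoxyphenyl in place of 2-methylphenyl on an aromatic nitrogen. Among the measured compounds shown here, this aryl group sits on the ring nitrogen far from the chain that was varied between compound 1 and compound 2, so the single measured step does not bear on it, and no measured pair shows what this kind of exchange does here. For the measured compounds named here, the only guidance is that the one change seen so far left the number essentially unchanged.

Without a relevant comparison, the estimate for compound 3 is expected to sit close to compound 1, with a step of a 1.1-fold higher number from compound 1 to compound 3 (0.04 log units; within the scatter), giving an expected value of 3500 nM and a range from 1200 nM to 10000 nM.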

Compound 3, half-maximal inhibitory concentration: 3730 nM
For compound 3 the middle estimate is 1.1-fold (0.03 log units) below the measured one; the range from low to high includes it.
By their numbers in this assay, from the lowest: compounds 1, 2 and 3 (each within the scatter of the next).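

In this assay the exchange on the aromatic nitrogen gives a 1.2-fold higher number from compound 1 to compound 3 (0.06 log units; within the scatter) and so leaves the two numbers indistinguishable. Among the compounds shown here, this is the first measured look at this place in the molecule, since the earlier pair varied only the saturated amine at the end of the chain. It shows that 4-methoxyphenyl can stand in place of 2-methylphenyl, bringing one more heavy atom and one hydrogen-bond acceptor by the count of the two groups, without a step beyond the usual scatter on this read-out. Nothing available explains this outcome.

The exchange alters two things at once, the kind of substituent on the phenyl ring and where it sits, so the compounds shown cannot separate the two, and a 4-methylphenyl or 2-methoxyphenyl group would be needed to do so. Going by these compounds, it also remains open whether this place responds at all to a more different group, such as an unsubstituted phenyl, a phenyl ring carrying a carboxylic acid or an amine, or a small alkyl chain instead of the aryl ring.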